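The compounds below may be only part of what the source reports. "The series", "measured", "known", "first", "only" and "open" are said of these compounds alone.

In a functional assay on the whole organism (strain Hartley) for inhibition, with Cavia porcellus as the target, with stated times of 2 min and 15 min (on this read-out higher numbers stand for an effect only at larger amounts of compound and lower numbers for an effect already at smaller amounts), compound 2 (`CCCCC[C@@H](O)/C=C/C1CCC(=O)[C@@H]1CCCCSCC(=O)O`) gives 0.0233 mg/kg, the higher of the two numbers, while compound 1 (`CCCCC[C@H](O)/C=C/C1CCC(=O)[C@@H]1CCCCSCC(=O)O`) gives 0.00129 mg/kg. Compound 3 (`CCCCC[C@](C)(O)/C=C/C1CCC(=O)[C@@H]1CCCCSCC(=O)O`) carries methyl in place of hydrogen on a saturated chain carbon bound to a double-bonded chain carbon, an oxygen on a saturated carbon and a saturated chain carbon. Among the compounds with values here, the only measured step, an 18-fold higher number from compound 1 to compound 2 (1.26 log units; beyond the scatter), is large and is a change of configuration at that same carbon. Within the data shown here, no methyl step has been measured, so a moderate drop in the number is expected, smaller than that step. The expected step is a 5.8-fold lower number from compound 2 to compound 3 (0.77 log units; beyond the scatter). The estimate for compound 3 is 0.004 mg/kg, with an expected range of 0.0005 mg/kg to 0.03 mg/kg.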

Compound 3, dose for half-maximal effect: 0.0054 mg/kg
For compound 3 the middle estimate is 1.4-fold (0.13 log units) below the measured one, and the stated range covers the measured number.
By their numbers in this assay, from the lowest: compound 1; then compound 3; then compound 2.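

In this assay, this saturated chain carbon accepts methyl in place of hydrogen, with a 4.3-fold lower number from compound 2 to compound 3 (0.63 log units; beyond the scatter). Compound 3 still falls short of the hydrogen-bearing compound 1, with a 4.2-fold higher number from compound 1 to compound 3 (0.62 log units; beyond the scatter). Nothing available bears on the reason for either step. Open, as far as these compounds go, is how the methyl compound with the opposite configuration at this carbon compares. Also open, from the compounds shown here alone, is whether an ethyl group there, or a methoxy group in place of the hydroxyl, would be accepted.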